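The source may hold more compounds than are shown below. What is called first, only, known or untested is meant among the compounds shown, and "the series" means these compounds.

Within the data shown here, compound 1 `COc1ccc(-n2nc(C(N)=O)nc2-c2cc(OC)c(OC)c(OC)c2)cc1` is one of three compounds measured in a functional assay on the whole organism for inhibition, with Rattus norvegicus as the target, read by paw edema, with stated times of 30 min and 2 h, at a dose of 0.28 mmol/kg by the oral route; on this read-out higher numbers stand for more inhibition at the one dose given (going by the name of the read-out) and lower numbers for less inhibition. On the numbers shown, compound 1 stands second highest of the three, giving 59%. Its nearest neighbour is compound 2 `COc1ccc(-n2nc(C(=O)Nc3ccc(C)cc3)nc2-c2cc(OC)c(OC)c(OC)c2)cc1`, which in this assay gives 60%; the furthest is compound 3 `COc1ccc(-n2nc(C(=O)Nc3ccc(C(F)(F)F)cc3)nc2-c2cc(OC)c(OC)c(OC)c2)cc1`, which gives 55%. The three steps between them are all small: a number 1 percentage points higher from compound 1 to compound 2 (within the scatter), a number 4 percentage points lower from compound 1 to compound 3 (within the scatter) and a number 5 percentage points lower from compound 2 to compound 3 (within the scatter).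

Compound 4 `COc1ccc(-n2nc(C(=O)Nc3ccc(C(=O)O)cc3)nc2-c2cc(OC)c(OC)c(OC)c2)cc1` has not yet been measured. It differs from compound 1 in one place: 4-carboxyphenyl in place of hydrogen on an amide-type nitrogen. Among the measured compounds shown here, the steps that bear on this change are the two in which the same hydrogen on the amide-type nitrogen was replaced by a 4-substituted phenyl, namely a number 1 percentage points higher from compound 1 to compound 2 (within the scatter) and a number 4 percentage points lower from compound 1 to compound 3 (within the scatter). Both lie within the scatter, so a third 4-substituted phenyl on that nitrogen is expected to leave this assay unchanged beyond the scatter. The step expected from compound 1 to compound 4 is therefore a number 2 percentage points lower from compound 1 to compound 4 (within the scatter). Compound 4 is accordingly estimated to give 57% in this assay, with a range from 44% to 70%.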

Compound 4, a percentage reported as inhibition, in the whole organism at one dose (the size of the read-out at that dose, not a potency): 57%
Compound 4: middle estimate and measured number agree at the digits printed, within the range that was stated.
By their numbers in this assay, from the lowest: compounds 3, 4, 1 and 2 (each within the scatter of the next).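

In this assay, a carboxy-bearing aryl group on the amide-type nitrogen fits the same picture as the earlier two, with 4-carboxyphenyl in place of hydrogen giving a number 2 percentage points lower from compound 1 to compound 4 (within the scatter) and so extending the flat result to a third 4-substituted phenyl. Changing only the group on the aromatic carbon also makes no difference beyond the scatter, whether carboxy replaces methyl, which gives a number 3 percentage points lower from compound 2 to compound 4 (within the scatter) or trifluoromethyl, which gives a number 2 percentage points higher from compound 3 to compound 4 (within the scatter) and thus across these three groups, none of the listed compounds goes against the flat pattern at this one dose. Nothing available here explains why the read-out stays so level across these changes.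

What the compounds leave open is whether any group at this position can move the read-out beyond the scatter, for example an amine on the phenyl ring in place of the carboxy, or a longer chain such as n-butyl on the amide-type nitrogen in place of the aryl group. A read-out at one dose also leaves open whether these four compounds would still look alike at other doses.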